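A New Substituent on a Compound at the Limit

The source may hold more compounds than are shown below. What is called first, only, known or untested is meant among the compounds shown, and "the series" means these compounds.

Measured so far in a functional assay on PANC-1 cells (Homo sapiens), read by microscopy, crystal violet staining and transwell migration, with a stated time of 18 h, in the presence of a further agent that is not named here; a lower number here means a stronger inhibitor, a higher number a weaker inhibitor:
- compound 1 `COc1ccc(-c2nc(C)nn2-c2cccc(C(=O)NCCCOc3ccccc3)c2)cc1` gives 3120 nM
- compound 2 `COc1ccc(-c2ncnn2-c2cccc(C(=O)NCCCCc3ccccc3)c2)cc1` gives > 20000 nM (a limit)

Compound 2 stands at > 20000 nM, which is a limit of the assay and not a number. For the measured compounds named here, no step between the two measured compounds is available. Compound 3 `COc1ccc(-c2nc(C(C)C)nn2-c2cccc(C(=O)NCCCCc3ccccc3)c2)cc1` differs from compound 2 by isopropyl in place of hydrogen on an aromatic carbon. In this assay a move towards stronger inhibition is expected, though compound 3 may also stay at the limit. Going by the values given here, this expectation leans on compound 1 at 3120 nM, the only true number available. The expected size of the change is an at least 3.3-fold lower number from compound 2 to compound 3 (0.52 log units; beyond the scatter), and it is uncertain, as there is no number to count from. The estimate for compound 3 is 6000 nM, with an expected range from 1500 nM to 20000 nM.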

Compound 3, half-maximal inhibitory concentration: > 20000 nM
Compound 3: no number, only a limit; the forecaster's own chance of this, stated with the estimate: 35%; middle value at least 3.3-fold (0.52 log units) away from the limit.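

Compound 3 gives > 20000 nM as a limit of the assay and not a number. Compound 2 also stands at a limit, so no step between compound 2 and compound 3 can be read: the limit of > 20000 nM in this assay, at which 2 of the 3 values shown sit.

The compounds shown leave open whether isopropyl in place of hydrogen on an aromatic carbon changes inhibition at all.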